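The source may hold more compounds than are shown below. What is called first, only, known or untested is meant among the compounds shown, and "the series" means these compounds.

Measured so far:
- compound 1 `O=C(/C(=C/c1ccc(Cl)cc1)CCl)c1ccccc1` — 22000 nM
- compound 2 `CCC(/C=C(\COC(C)=O)C(=O)c1ccccc1)CC` — 50000 nM
- compound 3 `CC(=O)OC/C(=C\c1ccccc1)C(=O)c1ccccc1` — 20000 nM

Of the compounds shown here, three sharing one core have been tested in a functional assay on HeLa cells (Homo sapiens) for inhibition, read by sulforhodamine B assay, with a stated time of 48 h; on this read-out higher numbers stand for weaker inhibition of growth and lower numbers for stronger inhibition of growth. Compound 3 gives the lowest of the three numbers, though its gap to compound 1 is within the scatter, and only its gap to compound 2 is beyond it. Within the data shown here, the one step that can be stated is a 2.5-fold lower number from compound 2 to compound 3 (0.40 log units; beyond the scatter), a modest move obtained by placing phenyl on a double-bonded chain carbon bound to a double-bonded chain carbon in place of pentan-3-yl.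

Compound 4 `CC(=O)OC/C(=C\c1ccc(Cl)cc1)C(=O)c1ccccc1` differs from compound 3 by chloro in place of hydrogen on an aromatic carbon, on an aromatic carbon of a six-membered aromatic ring of carbon only, para to a large group. Among the measured compounds shown here, no measured pair changes only this. Compound 1 already carries the chlorine but also a different chain group, and its value in this assay and that of compound 3 sit within the scatter of each other, so nothing here points to a shift from the chloro alone. The step of a 2.5-fold lower number from compound 2 to compound 3 (0.40 log units; beyond the scatter) concerns a different site and bears on it only by showing that changes on this chain carbon are modest.

Compound 4 is therefore expected to give 18000 nM, between 8000 nM and 40000 nM, with the expected step of a 1.1-fold lower number from compound 3 to compound 4 (0.05 log units; within the scatter) being no more than the scatter.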

Compound 4, concentration for 50% growth inhibition: 3200 nM
The estimate for compound 4 lay 5.6-fold (0.75 log units) above the measured number; the whole stated range lies above it.
By their numbers in this assay, from the lowest: compound 4; then compounds 3 and 1 (each within the scatter of the next); then compound 2.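

In this assay, among these compounds, the change from phenyl to 4-chlorophenyl, chloro in place of hydrogen on an aromatic carbon para to a large group, gives a 6.3-fold lower number from compound 3 to compound 4 (0.80 log units; beyond the scatter) and is the first measured step at this place on the ring, showing that this site responds more than the earlier compounds could indicate. Among the compounds shown here, with the 4-chlorophenyl held constant, the chain group also counts: acetoxy in place of chloro on the saturated chain carbon gives a 6.9-fold lower number from compound 1 to compound 4 (0.84 log units; beyond the scatter) while 4-chlorophenyl in place of pentan-3-yl gives a 16-fold lower number from compound 2 to compound 4 (1.19 log units; beyond the scatter) as the only large step among the new ones. Nothing measured here explains the size of the chloro step.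

On these data alone, whether this step belongs to chloro itself or would also follow with fluoro, methoxy or a nitrile at the same place remains open, as does the response of the other aromatic carbons of the ring. As far as these compounds go, it is also open how a hydroxyl or an amine on the saturated chain carbon would compare with acetoxy.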